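The compounds below may be only part of what the source reports. "The series", "measured", "known", "first", "only" and "open" are said of these compounds alone.

Measured compounds:
compound 1, `COc1cccc(-n2cc(C(=O)c3cc(OC)c(OC)c(OC)c3)c(-c3ccccc3)c2)c1`: 500 nM
compound 2, `COc1cc(C(=O)c2cn(-c3ccccc3)cc2-c2cccc(Br)c2)cc(OC)c1OC`: 950 nM

In a functional assay on MCF7 cells (Homo sapiens) for cytotoxicity, read by MTT assay, with a stated time of 96 h (on this read-out higher numbers stand for weaker inhibition and lower numbers for stronger inhibition), compound 2 gives 950 nM, and this number sits within the usual scatter of the number of compound 1, so the two cannot be told apart. Compound 3 is `COc1cc(C(=O)c2cn(-c3ccccc3)cc2-c2cc(F)ccc2F)cc(OC)c1OC`. It differs from compound 2 in one place: 2,5-difluorophenyl in place of 3-bromophenyl on an aromatic carbon. Among the measured compounds shown here, with only two measured compounds that do not separate, there is no basis to expect a step beyond the scatter in this assay. The step of a 1.1-fold lower number from compound 2 to compound 3 (0.02 log units; within the scatter) is therefore expected to be small, and compound 3 is estimated at 900 nM, likely between 350 nM and 2500 nM.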

Compound 3, half-maximal inhibitory concentration: 230 nM
Beside the measured number, compound 3's estimate is 3.9-fold (0.59 log units) above it; the measured number lies below the stated range.
By their numbers in this assay, from the lowest: compound 3; then compounds 1 and 2 (each within the scatter of the next).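

In this assay, the group on this aromatic carbon of the shared core clearly matters: 2,5-difluorophenyl in place of 3-bromophenyl gives a 4.1-fold lower number from compound 2 to compound 3 (0.62 log units; beyond the scatter) and so a real gain in potency. Among the compounds shown here, the earlier compounds offered no comparison of a single change, so this is the first evidence that the position responds to its aryl group. Nothing available here explains the drop in the number.

From the compounds shown here alone, it remains open whether one fluorine alone would give the same result. How an amine such as morpholine or a carboxylic acid would read at this carbon is also unknown.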